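Three aryloxypropyl ethers on a shared core, a fourth to come

This account rests on a few compounds, and the source may have more. Where it says the series, first, only, none or still open, it means among the compounds named here.

Three compounds share one core and differ only in the aryl group carried on an oxygen on a saturated carbon. Compound 1 `NC1=NC2(CCSCC2)N(OCCCOc2cc(Cl)c(Cl)cc2Cl)C(N)=N1` gives 84.4% in an assay on isolated protein for inhibition of Dihydrofolate reductase (Homo sapiens), read by spectrophotometry, using NADPH, with stated times of 5 s and 6 min, tested at 5 uM (a higher number here means a stronger effect of the compound at the concentration tested, a lower number a weaker effect), compound 2 `NC1=NC2(CCSCC2)N(OCCCOc2ccccc2Cl)C(N)=N1` gives 86.3%, and compound 3 `NC1=NC2(CCSCC2)N(OCCCOc2cccc(Br)c2)C(N)=N1` gives 84.2%. Compound 3 stands at the foot of these three numbers, but only by steps that the scatter swallows: a number 0.2 percentage points lower from compound 1 to compound 3 (within the scatter) and a number 2.1 percentage points lower from compound 2 to compound 3 (within the scatter); the remaining pair shows a number 1.9 percentage points higher from compound 1 to compound 2 (within the scatter). The untested compound 4 `NC1=NC2(CCSCC2)N(OCCCOc2ccc(Cl)c(Cl)c2)C(N)=N1` differs from compound 3 in one place: 3,4-dichlorophenyl in place of 3-bromophenyl on an oxygen on a saturated carbon. Within the data shown here, the steps that bear on this change are the two aryl swaps ending at compound 3, a number 0.2 percentage points lower from compound 1 to compound 3 (within the scatter) and a number 2.1 percentage points lower from compound 2 to compound 3 (within the scatter), both within the scatter, and the swap a number 1.9 percentage points higher from compound 1 to compound 2 (within the scatter), also within the scatter. Since no aryl exchange among these three has moved the inhibition beyond the scatter, compound 4 is expected to show a step of a number 0.8 percentage points higher from compound 3 to compound 4 (within the scatter), no direction beyond the scatter. For compound 4 the estimate is 85%, with a range from 76% to 93%.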

Compound 4, a percentage reported as inhibition, at one concentration (the size of the read-out at that concentration, not a potency): 88.4%
Beside the measured number, compound 4's estimate is 3.4 percentage points below it; the range from low to high includes it.
By their numbers in this assay, from the lowest: compounds 3, 1, 2 and 4 (each within the scatter of the next).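

The 3,4-dichlorophenyl group, with two chlorines where compound 3 carries one bromine, keeps the read-out in this assay within the scatter of all three earlier aryl groups (a number 4.2 percentage points higher from compound 3 to compound 4 (within the scatter); a number 2.1 percentage points higher from compound 2 to compound 4 (within the scatter); a number 4 percentage points higher from compound 1 to compound 4 (within the scatter)). The step from the 2,4,5-trichlorophenyl compound, hydrogen in place of chloro on an aromatic carbon, is also within the scatter, so this position has now taken four halogenated aryl groups without a step beyond it. Nothing available here bears on why these changes leave the number within the scatter.

As far as these compounds go, all four aryl groups carry only halogens, so a phenyl bearing an amine, a carboxylic acid or a methoxy group remains open, as does a longer chain on the oxygen. From the compounds shown here alone, each number is also a read-out at one concentration, so any difference in potency among the four remains open.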